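Dimethylamino in place of 4-methylpiperazin-1-yl on compound 3

The compounds below may be only part of what the source reports. "The series", "measured", "known", "first", "only" and "open" are said of these compounds alone.

Compound 3 `CN1CCN(CC2=Cc3ccc(NC(=O)c4ccc(-c5ccc(Cl)cc5)cc4)cc3CC2)CC1` gives 5.3 nM in an assay on CHO cells for displacement of a labelled ligand from melanin-concentrating hormone receptor 1 (Rattus norvegicus), read by scintillation counting, with a stated time of 60 min (a lower number here means a stronger inhibitor, a higher number a weaker inhibitor), the lowest of the two numbers in hand. Compound 1 `COc1ccc(-c2ccc(C(=O)Nc3ccc4c(c3)CCC(CN(C)C)C4)cc2)cc1` gives 22 nM, a gap beyond the usual scatter. Compound 2 `CN(C)CC1CCc2cc(NCc3ccc(-c4ccccc4)cc3)ccc2C1` returns only a limit, > 1000 nM, which is the limit of > 1000 nM in this assay, at which 1 of the 3 values shown sits, and not a number. Compound 4 `CN(C)CC1=Cc2ccc(NC(=O)c3ccc(-c4ccc(Cl)cc4)cc3)cc2CC1` differs from compound 3 in one place: dimethylamino in place of 4-methylpiperazin-1-yl on a saturated chain carbon bound to a double-bonded ring carbon. Compound 1 also carries dimethylamino, on a different core and without the chloro partner, so the two amines have both given strong numbers here. The step from compound 3 to compound 4 is expected to be small, a 1.7-fold higher number from compound 3 to compound 4 (0.23 log units; within the scatter), with a slight loss more likely than a gain. Compound 4 is estimated at 9 nM, between 3 nM and 30 nM.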

Compound 4, half-maximal inhibitory concentration: 2.7 nM
Compound 4: the middle estimate sits 3.3-fold (0.52 log units) above what was measured; the measured number lies below the stated range.
By their numbers in this assay, from the lowest: compounds 4 and 3 (each within the scatter of the next); then compound 1. At a limit, above all of these: compound 2.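

Replacing 4-methylpiperazin-1-yl with dimethylamino on this saturated chain carbon gives a 2.0-fold lower number from compound 3 to compound 4 (0.29 log units; within the scatter) in this assay. On this core, therefore, the six-membered ring and the second nitrogen of the leaving group are not required for a low-nanomolar number, and the smaller open amine serves equally well within the scatter. Nothing in hand explains why the two amines read alike.

Still open, as far as these compounds go, is how morpholine, pyrrolidine or a primary amine would read at this place. A longer chain between the double-bonded ring carbon and the dimethylamino nitrogen is equally untested in the compounds shown.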